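Replacing a 4-chlorophenyl with tert-butyl: an expectation

A few compounds are considered here, and "the series" means these few. Any claim that something is new, unique, unknown or untested is made for them only; others in the source may bear on it.

Three measured compounds share one core and differ in a single group. In an in vitro functional assay on cells for agonist activity at Bombesin receptor subtype-3 (Mus musculus), read by luminescence and calcium flux (on this read-out lower numbers stand for an effect already at smaller amounts and higher numbers for an effect only at larger amounts of compound), compound 1 `Cc1ccccc1Cc1cnc(CCc2ccc(-c3ccccc3C(=O)O)cc2)[nH]1` gives 9.3 nM, compound 2 `O=C(O)c1ccccc1-c1ccc(CCc2ncc(CC3CCCC3)[nH]2)cc1` gives 7.9 nM, and compound 3 `O=C(O)c1ccccc1-c1ccc(CCc2ncc(Cc3ccc(Cl)cc3)[nH]2)cc1` gives 102 nM, the highest of the three numbers. The steps of an 11-fold higher number from compound 1 to compound 3 (1.04 log units; beyond the scatter) and a 13-fold higher number from compound 2 to compound 3 (1.11 log units; beyond the scatter) both show the 4-chlorophenyl paired with far higher numbers than 2-methylphenyl or cyclopentyl. Compound 4 `CC(C)(C)Cc1cnc(CCc2ccc(-c3ccccc3C(=O)O)cc2)[nH]1` carries tert-butyl in place of 4-chlorophenyl on a saturated chain carbon bound to an aromatic carbon. This change removes the 4-chlorophenyl in favour of a saturated group, running opposite to the change seen from compound 2 to compound 3, so a large move to a lower number is expected. Compound 4 is therefore estimated at 15 nM in this assay, between 5 nM and 60 nM, an expected step of a 6.8-fold lower number from compound 3 to compound 4 (0.83 log units; beyond the scatter).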

Compound 4, half-maximal effective concentration: 6.3 nM
Compound 4: the middle estimate sits 2.4-fold (0.38 log units) above what was measured; the measured number falls inside the stated range.
By their numbers in this assay, from the lowest: compounds 4, 2 and 1 (each within the scatter of the next); then compound 3.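

In this assay, tert-butyl undoes the rise seen with 4-chlorophenyl (a 16-fold lower number from compound 3 to compound 4 (1.21 log units; beyond the scatter)) and cannot be told apart from the other two groups (a 1.3-fold lower number from compound 2 to compound 4 (0.10 log units; within the scatter); a 1.5-fold lower number from compound 1 to compound 4 (0.17 log units; within the scatter)). On a saturated chain carbon bound to an aromatic carbon, a group with no ring therefore reads like cyclopentyl or 2-methylphenyl, leaving compound 3 alone among the four with a higher number. No evidence on the cause is available. Still open, from the compounds shown here alone, is whether the chlorine accounts for that higher number, and how an unsubstituted phenyl or an amine would read at this place.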